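The source may report more compounds than this note shows. Statements on the series, on what has been measured and on what is new or still open speak of the compounds shown alone.

Three compounds share one core and differ only in the group attached to the carbonyl carbon. Compound 3 `O=C(OC1CCC(CN2CCN(c3cc(=O)c4cc(C(F)(F)F)cc([N+](=O)[O-])c4s3)CC2)CC1)c1ccccc1` stands highest of the three: in an ADME assay on cells (Hepatocyte, Homo sapiens) for metabolic stability (a higher number here means that the compound lasts longer, a lower number that the compound disappears faster), compound 3 gives 0.603 h. Compound 1 `O=C(OC1CCC(CN2CCN(c3cc(=O)c4cc(C(F)(F)F)cc([N+](=O)[O-])c4s3)CC2)CC1)c1ccco1` gives 0.075 h in this assay, and compound 2 `COc1ccc(C(=O)OC2CCC(CN3CCN(c4cc(=O)c5cc(C(F)(F)F)cc([N+](=O)[O-])c5s4)CC3)CC2)cc1` gives 0.165 h. The measured steps all lie beyond the scatter: an 8.0-fold higher number from compound 1 to compound 3 (0.91 log units; beyond the scatter), a 3.7-fold higher number from compound 2 to compound 3 (0.56 log units; beyond the scatter) and a 2.2-fold higher number from compound 1 to compound 2 (0.34 log units; beyond the scatter).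

Compound 4 `O=C(NC1CCC(CN2CCN(c3cc(=O)c4cc(C(F)(F)F)cc([N+](=O)[O-])c4s3)CC2)CC1)c1ccccc1` keeps the phenyl on the carbonyl carbon and instead changes the link to the saturated ring: benzamido in place of benzoyloxy on a saturated ring carbon. Among the compounds with values here, none of the measured steps touches this link; each of them only exchanges the aromatic group on the carbonyl carbon. So the three steps bear on the change to compound 4 only indirectly, by showing that a single change near the carbonyl can move the half-life beyond the scatter in this assay, while they say nothing about the direction of swapping an ester for an amide.

Within the data shown here, with no direct precedent, a modest rise is expected, and the step of a 3.3-fold higher number from compound 3 to compound 4 (0.52 log units; beyond the scatter) is an estimate with wide uncertainty. For compound 4 in this assay the expected value is 2 h, with a range from 0.6 h to 6 h.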

Compound 4, half-life: > 1.55 h
Compound 4: only a limit was reported (the forecaster's own chance of this, stated with the estimate: 10%); the middle value is on the limit's open side.
By their numbers in this assay, from the lowest: compound 1; then compound 2; then compound 3. At a limit, above all of these: compound 4.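

For compound 4, this assay gives a limit and not a number: the limit of > 1.55 h in this assay, at which 1 of the 4 values shown sits. Within the data shown here, with the phenyl on the carbonyl carbon kept, exchanging benzoyloxy for benzamido gives an at least 2.5-fold higher number from compound 3 to compound 4 (0.41 log units; beyond the scatter), which shows for the first time that the link to the saturated ring, and not only the aromatic group on the carbonyl carbon, can move the half-life beyond the scatter, here in the direction of a longer-lasting compound. The amide also stands clear of the two other esters, which differ from it in both the link and the aromatic group, with an at least 9.3-fold higher number from compound 2 to compound 4 (0.97 log units; beyond the scatter) and an at least 20-fold higher number from compound 1 to compound 4 (1.31 log units; beyond the scatter).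

These steps give only a lower bound, so the true size of the gain from the amide link stays unknown, and the compounds shown do not tell whether that gain would carry over to the furan-2-yl or 4-methoxyphenyl groups on the carbonyl carbon. They also leave open how other links on the same saturated ring carbon would behave, such as a plain amine, an ether or a sulfonamide, and what in the exchange of ester for amide lies behind the longer half-life.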